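Compound 4: a rearranged fluoropyridine on the sulfonyl sulfur

The source may report more compounds than this note shows. Statements on the series, on what has been measured and on what is new or still open speak of the compounds shown alone.

In an ADME assay on the whole organism (plasma, Rattus norvegicus, strain Sprague-Dawley) for pharmacokinetics, read by LC-MS, using cassette dosing, at a dose of 0.2 mg/kg by the intravenous route (on this read-out higher numbers stand for higher exposure at the dose given and lower numbers for lower exposure), compound 1 `CNCc1cn(S(=O)(=O)c2cccc(OC)n2)c(-c2cccnc2F)c1F` gives 50 ng.h/mL, compound 2 `CNCc1cn(S(=O)(=O)c2cccc(C)n2)c(-c2cccnc2F)c1F` gives 41 ng.h/mL and compound 3 `CNCc1cn(S(=O)(=O)c2ccc(F)cn2)c(-c2cccnc2F)c1F` gives 22 ng.h/mL. Compound 3 stands clearly apart only from compound 1, with a 2.3-fold lower number from compound 1 to compound 3 (0.36 log units; beyond the scatter), while the other comparison shows a 1.9-fold lower number from compound 2 to compound 3 (0.27 log units; within the scatter). Compound 4 `CNCc1cn(S(=O)(=O)c2cncc(F)c2)c(-c2cccnc2F)c1F` has the same atoms as compound 3, joined differently: 5-fluoropyridin-3-yl in place of 5-fluoropyridin-2-yl on a sulfonyl sulfur, with 5-fluoropyridin-3-yl in place of 5-fluoropyridin-2-yl on a sulfonyl sulfur. Both steps above also replace the group on that sulfur, and the larger is only modest, though neither tests this exact swap. No step beyond the scatter is therefore expected, and the estimated change is a 1.3-fold higher number from compound 3 to compound 4 (0.10 log units; within the scatter). Compound 4 is estimated at 28 ng.h/mL, with an expected range of 13 ng.h/mL to 60 ng.h/mL.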

Compound 4, area under the concentration-time curve: 38 ng.h/mL
Compound 4: middle estimate off by 1.4-fold (0.13 log units), on the low side; low and high end bracket the measured number.
By their numbers in this assay, from the lowest: compounds 3, 4, 2 and 1 (each within the scatter of the next, the first and the last beyond it).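

In this assay, 5-fluoropyridin-3-yl in place of 5-fluoropyridin-2-yl on a sulfonyl sulfur, the same atoms joined differently, gives a step within the scatter (a 1.7-fold higher number from compound 3 to compound 4 (0.24 log units; within the scatter)), so moving the ring's attachment this way cannot be told from repeat-measurement noise. Compound 4 also lies within the scatter of the other two compounds (a 1.1-fold lower number from compound 2 to compound 4 (0.03 log units; within the scatter); a 1.3-fold lower number from compound 1 to compound 4 (0.12 log units; within the scatter)), whereas compound 3 stands apart from compound 1. Nothing measured here offers an explanation for these numbers. Still open, on these data alone, is whether a phenyl ring or a pyridine carrying an amine or a carboxylic acid on this sulfur would move the number beyond the scatter.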